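The source may hold more compounds than are shown below. What is called first, only, known or untested is meant among the compounds shown, and "the series" means these compounds.

Measured in a functional assay on K562 cells (Homo sapiens) for antiproliferative activity, with a stated time of 72 h; on this read-out lower numbers stand for stronger inhibition and higher numbers for weaker inhibition:
- Compound 1 `CCCCC#Cc1cc([C@@H]2O[C@H](CO)[C@@H](O)[C@H]2O)n2ncnc(N)c12`: 2400 nM
- Compound 2 `Nc1ncnn2c([C@@H]3O[C@H](CO)[C@@H](O)[C@H]3O)cc(C#Cc3cccs3)c12`: > 100000 nM (a limit)
- Compound 3 `Cc1ccccc1-c1cc([C@@H]2O[C@H](CO)[C@@H](O)[C@H]2O)n2ncnc(N)c12`: > 100000 nM (a limit)

Compound 3 has no exact number and stands at the limit of > 100000 nM in this assay, at which 2 of the 3 values shown sit.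

Compound 4 `Nc1ncnn2c([C@@H]3O[C@H](CO)[C@@H](O)[C@H]3O)cc(-c3ccoc3)c12` carries furan-3-yl in place of 2-methylphenyl on an aromatic carbon.

Going by the values given here, two measured steps bear on this change. The first is large: an at least 41-fold higher number from compound 1 to compound 3 (1.61 log units; beyond the scatter). The second is also large: an at least 41-fold higher number from compound 1 to compound 2 (1.61 log units; beyond the scatter). Neither tests furan-3-yl, but together they show that changing the group at this place can move the read-out widely. Compound 1 reaches a readable 2400 nM with the shared core, so a large move toward a lower number is expected. Compound 4 could also stay at the limit.

The expected change is an at least 12-fold lower number from compound 3 to compound 4 (1.09 log units; beyond the scatter).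

For compound 4, the estimated value is 8000 nM, with an expected range from 300 nM to 100000 nM.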

Compound 4, half-maximal inhibitory concentration: 2100 nM
The estimate for compound 4 lay 3.8-fold (0.58 log units) above the measured number; measured number inside the range.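

A ring attached directly at this place need not cost the activity: furan-3-yl in place of 2-methylphenyl gives an at least 47-fold lower number from compound 3 to compound 4 (1.67 log units; beyond the scatter). Furan-3-yl in place of 2-(thiophen-2-yl)ethynyl likewise gives an at least 47-fold lower number from compound 2 to compound 4 (1.67 log units; beyond the scatter). Against hex-1-yn-1-yl there is a 1.1-fold lower number from compound 1 to compound 4 (0.06 log units; within the scatter), so a triple bond at this place is not needed for a readable value.

Still open, going by these compounds, is whether the oxygen of furan-3-yl or the smaller size of the group separates compound 4 from compound 3. A plain phenyl or a thiophen-3-yl group at this place would help to tell these apart.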